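Shortening the Amine Chain on a Flavone Ether

The compounds below may be only part of what the source reports. "The series", "measured", "known", "first", "only" and "open" are said of these compounds alone.

The shared core here is a flavone ether bearing a basic amine at the end of a three-carbon chain. Compound 1, `CCN(CC)CCCOc1c(O)cc(O)c2c(=O)cc(-c3ccccc3)oc12`, is tested in a functional assay on A549 cells (Homo sapiens) for cytotoxicity, read by MTT assay, with a stated time of 48 h; a lower number here means a stronger inhibitor, a higher number a weaker inhibitor. In this assay compound 1 gives only a limit of the assay, > 100000 nM, not a number. Of the three results shown, this sits at the limit of > 100000 nM in this assay, at which 1 of the 3 values shown sits. Compound 2, `COc1c(OCCCCNCc2ccccc2)cc(O)c2c(=O)cc(-c3ccccc3)oc12`, gives 4590 nM in this assay. Compound 3, `COc1ccc(-c2cc(=O)c3c(O)cc(O)c(OC)c3o2)cc1`, has no result in this assay, recorded as "not determined" (no result reported).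

Compound 4, `CN(C)CCCOc1c(O)cc(O)c2c(=O)cc(-c3ccccc3)oc12`, has not yet been measured. It differs from compound 1 in one place: dimethylamino in place of diethylamino on a saturated chain carbon, three bonds along the chain from an oxygen on an aromatic ring. For the measured compounds named here, no step between measured compounds matches this change, so nothing here shows how much a diethylamino to dimethylamino swap moves the read-out. The change is expected to move the value by no more than the usual scatter, in no fixed direction, as a step that the limit leaves unreadable from compound 1 to compound 4. Compound 4 is therefore expected to give about 150000 nM, within 40000 nM to 600000 nM, and most likely again only a limit.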

Compound 4, half-maximal inhibitory concentration: > 100000 nM
Compound 4: a limit, no number; the forecaster's own chance of this, stated with the estimate: 70%; the middle value is on the limit's open side.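

In this assay, for the compounds shown here, compound 1 and compound 4 each give only a limit of the assay and not a number, so no step between them can be read: the limit of > 100000 nM in this assay, at which 2 of the 4 values shown sit. The compounds shown leave open whether dimethylamino in place of diethylamino changes the read-out at all.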